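The source may report more compounds than this note shows. Statements on the series, on what has been measured and on what is new or still open speak of the compounds shown alone.

Compound 1, `COc1cc(NCc2ccccc2)cc(OC)c1OC`, stands at > 80000 nM in a functional assay on KYSE-450 cells (Homo sapiens) for inhibition, read by MTT assay, with a stated time of 48 h (a higher number here means a weaker inhibitor, a lower number a stronger inhibitor), which is a limit of the assay and not a number.
Compound 2, `C/C=C/C(=O)N(Cc1cc(OC)c(OC)c(OC)c1)c1ccc(OC)c(O)c1`, gives 9160 nM in this assay.
Compound 3, `C#CC(=O)N(Cc1ccc(OC)c(O)c1)c1cc(OC)c(OC)c(OC)c1`, gives 570 nM in this assay.

Among the two numbers shown, compound 3 has the lower one; the nearest is compound 2, whose number is higher by a margin beyond the usual scatter. Compound 4, `C=CC(=O)N(Cc1ccc(OC)c(O)c1)c1cc(OC)c(OC)c(OC)c1`, differs from compound 3 in one place: vinyl in place of ethynyl on a carbonyl carbon. Going by the values given here, no pair of measured compounds shows this change, so its effect is unknown. In this assay a small rise is expected, close to the scatter. Compound 4 is expected to give 1200 nM, with a likely range from 300 nM to 5000 nM. The expected step is a 2.1-fold higher number from compound 3 to compound 4 (0.32 log units; beyond the scatter).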

Compound 4, half-maximal inhibitory concentration: 160 nM
Compound 4: middle estimate off by 7.5-fold (0.88 log units), on the high side; measured number outside the range, below it.
By their numbers in this assay, from the lowest: compound 4; then compound 3; then compound 2. At a limit, above all of these: compound 1.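

In this assay vinyl in place of ethynyl on a carbonyl carbon gives a 3.6-fold lower number from compound 3 to compound 4 (0.55 log units; beyond the scatter) and so a stronger inhibitor. Going by these compounds alone, this is the first reading of any change at this place, and it shows that the triple bond is not required for activity here, since the double bond does better. Nothing measured here accounts for the step. As far as these compounds go, only ethynyl and vinyl can be compared on this carbonyl carbon, so the effect of an ethyl group, or of a longer chain carrying an amine, remains open. From the compounds shown here alone, whether the step holds in other cell lines also remains open.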